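Terminal amine variation on the shared core: compound 4

This account rests on a few compounds, and the source may have more. Where it says the series, first, only, none or still open, it means among the compounds named here.

Three compounds of the series share one core and differ only at the amine that ends the chain attached through an oxygen on the aromatic ring. Compound 1 `COc1c(OCCCN2CCNCC2)cc(O)c2c(=O)cc(-c3ccccc3)oc12` gives 10100 nM in a functional assay on A549 cells (Homo sapiens) for cytotoxicity, read by MTT assay, with a stated time of 48 h; a higher number here means a weaker inhibitor, a lower number a stronger inhibitor. Compound 2 `CCN(CC)CCCOc1cc(O)c2c(=O)cc(-c3ccccc3)oc2c1OC` gives 1830 nM in that assay, and compound 3 `COc1c(OCCCCNCc2ccccc2)cc(O)c2c(=O)cc(-c3ccccc3)oc12` gives 4590 nM. Compound 3 therefore stands second highest of the three numbers: it shows a 2.2-fold lower number from compound 1 to compound 3 (0.34 log units; beyond the scatter) and a 2.5-fold higher number from compound 2 to compound 3 (0.40 log units; beyond the scatter). The strongest step in the set is a 5.5-fold lower number from compound 1 to compound 2 (0.74 log units; beyond the scatter).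

Compound 4 `COc1c(OCCCCN2CCCC2)cc(O)c2c(=O)cc(-c3ccccc3)oc12` is not yet measured. It differs from compound 3 as follows: pyrrolidin-1-yl in place of benzylamino on a saturated chain carbon, four bonds along the chain from an oxygen on an aromatic ring. Among the measured compounds shown here, no measured step bears on exactly this exchange. The three measured steps all concern the same chain end and are each modest in size, so a change of similar size is expected here. Because compound 2 gives 1830 nM with a chain-end amine that, like pyrrolidin-1-yl, carries no benzyl group, a somewhat lower number than compound 3 is expected. The expected step is a 1.8-fold lower number from compound 3 to compound 4 (0.26 log units; within the scatter), modest and within the span already seen. Compound 4 is thus estimated at 2500 nM in that assay, with a range from 1000 nM to 6500 nM.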

Compound 4, half-maximal inhibitory concentration: 1530 nM
Compound 4: middle estimate off by 1.6-fold (0.21 log units), on the high side; measured number inside the range.
By their numbers in this assay, from the lowest: compounds 4 and 2 (each within the scatter of the next); then compound 3; then compound 1.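

In this assay, pyrrolidin-1-yl in place of benzylamino on a saturated chain carbon, four bonds along the chain from an oxygen on an aromatic ring, gives a 3.0-fold lower number from compound 3 to compound 4 (0.48 log units; beyond the scatter), so the benzylamino end of compound 3 is not needed to hold the number down. The exchange of diethylamino for (pyrrolidin-1-yl)methyl gives a 1.2-fold lower number from compound 2 to compound 4 (0.08 log units; within the scatter), which places an open-chain amine end and a ring amine end level with each other, so a low number at this position is not tied to one of these two shapes. The exchange of piperazin-1-yl for (pyrrolidin-1-yl)methyl gives a 6.6-fold lower number from compound 1 to compound 4 (0.82 log units; beyond the scatter), the largest step seen so far, and it leaves compound 1 with the highest number of the four, clear of every other compound in the set.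

No measurement on these compounds accounts for any of these steps. Still open, on these data alone, is whether a piperidin-1-yl or morpholin-4-yl end would stay level with compound 2 and compound 4 or move towards compound 1, and whether a longer chain carrying pyrrolidin-1-yl would keep the number where it now stands.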